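This account rests on a few compounds, and the source may have more. Where it says the series, first, only, none or still open, it means among the compounds named here.

In a functional assay on HepG2 cells (Homo sapiens) for cytotoxicity, read by MTT assay, with a stated time of 24 h (on this read-out higher numbers stand for weaker inhibition and lower numbers for stronger inhibition), compound 1 `Cc1ccc(S(=O)(=O)N2C/C(=C\c3ccncc3)C(=O)/C(=C/c3ccccc3F)C2)cc1` gives 9700 nM, compound 2 `O=C1/C(=C/c2ccncc2)CN(S(=O)(=O)c2ccc([N+](=O)[O-])cc2)C/C1=C\c1ccccc1F` gives 11300 nM, and compound 3 `O=C1/C(=C/c2ccncc2)CN(S(=O)(=O)c2ccc(F)cc2)C/C1=C\c1ccccc1F` gives 20300 nM. Compound 2 lies within the scatter of the other two, as shown by a 1.2-fold higher number from compound 1 to compound 2 (0.07 log units; within the scatter) and a 1.8-fold higher number from compound 2 to compound 3 (0.25 log units; within the scatter). Compound 4 `O=C1/C(=C/c2ccncc2)CN(S(=O)(=O)c2ccc([N+](=O)[O-])cc2)C/C1=C\c1ccccc1C(F)(F)F` keeps the nitro group of compound 2 but has trifluoromethyl in place of fluoro on an aromatic carbon. For the measured compounds named here, no measured step changes this place, so they bear on it only indirectly. They exchange a different aromatic substituent, and even the largest, a 2.1-fold higher number from compound 1 to compound 3 (0.32 log units; beyond the scatter), is modest. No step beyond the scatter is therefore expected in this assay. Compound 4 is estimated at 11000 nM, with an expected range of 5000 nM to 24000 nM. This estimate means an expected 1.0-fold lower number from compound 2 to compound 4 (0.01 log units; within the scatter).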

Compound 4, half-maximal inhibitory concentration: 13400 nM
For compound 4 the middle estimate is 1.2-fold (0.09 log units) below the measured one; measured number inside the range.
By their numbers in this assay, from the lowest: compounds 1, 2, 4 and 3 (each within the scatter of the next, the first and the last beyond it).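

In this assay, for the compounds shown here, the exchange of 2-fluorophenyl for 2-(trifluoromethyl)phenyl is the first measured change at this place, and it gives a 1.2-fold higher number from compound 2 to compound 4 (0.07 log units; within the scatter) in the series. Here, on an aromatic carbon ortho to a large group, trifluoromethyl with its four heavy atoms replaces fluoro with its one, and the number stays within the scatter. Going by these compounds, whether an amine or a carboxylic acid at this place would do the same remains open, as does whether this step holds with the methyl of compound 1 or the fluoro of compound 3 in place of the nitro group. No measurement shown here offers an explanation for this result.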